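The source may report more compounds than this note shows. Statements on the series, on what has been measured and on what is new or still open speak of the compounds shown alone.

Measured in a functional assay on the whole organism with Mus musculus as the target; a higher number here means that more compound is needed for the effect, a lower number that less compound is needed:
- compound 1 `CCCn1c(-c2ccc(Cl)cc2)nn(C)c1=S` gives 12.5 mg/kg on record
- compound 2 `CCn1c(-c2ccccc2)nn(C)c1=S` gives 1.2 mg/kg on record
- compound 3 `Cn1nc(-c2ccc(Cl)cc2)n(C)c1=S` gives 0.27 mg/kg on record

Compound 3 stands at 0.27 mg/kg in this assay and so has the lowest of the three numbers, beyond the scatter from both others. Compound 4 `CCn1c(-c2ccc(Cl)cc2)nn(C)c1=S` differs from it in one place, with methyl in place of hydrogen on a saturated chain carbon bound to an aromatic nitrogen, which turns methyl into ethyl. Within the data shown here, the only measured step at this place is a 46-fold lower number from compound 1 to compound 3 (1.67 log units; beyond the scatter) and it is large. It shortens the chain by more than the new change lengthens it, so compound 4 should recover only part of that gap. Compound 2 also carries ethyl but differs elsewhere, and it stands at 1.2 mg/kg in this assay as a rough guide. A higher number beyond the scatter is therefore expected, though a smaller step than the measured one. The estimate for the step is a 4.8-fold higher number from compound 3 to compound 4 (0.68 log units; beyond the scatter) in this assay as a whole. Compound 4 is expected at 1.3 mg/kg with an estimated range (0.45 mg/kg to 4.5 mg/kg).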

Compound 4, dose for half-maximal effect: 21.2 mg/kg
Estimate against measurement, compound 4: 16-fold (1.21 log units) below, outside the stated range (above it).
By their numbers in this assay, from the lowest: compound 3; then compound 2; then compounds 1 and 4 (each within the scatter of the next).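

In this assay, nearly the whole change at this position comes with methyl in place of hydrogen on a saturated chain carbon bound to an aromatic nitrogen, which turns methyl into ethyl (a 79-fold higher number from compound 3 to compound 4 (1.89 log units; beyond the scatter)). The next carbon along the chain adds nothing that can be told apart (a 1.7-fold higher number from compound 1 to compound 4 (0.23 log units; within the scatter)), so with chloro on the aromatic ring the earlier large step from compound 1 to compound 3 belongs almost entirely to the change from methyl to ethyl. With ethyl held constant, chloro in place of hydrogen on an aromatic carbon also counts for much (an 18-fold higher number from compound 2 to compound 4 (1.25 log units; beyond the scatter)). The compounds shown leave open how a branched isopropyl or a cyclopropyl group would read at this position, and how methoxy would read in place of chloro. Nothing available explains these steps.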